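Cyclopropyl hydroxamic acid on the phenoxybenzylamine series

The source may report more compounds than this note shows. Statements on the series, on what has been measured and on what is new or still open speak of the compounds shown alone.

Going by the values given here, compound 3 `CN(C)C(=O)CCc1ccc(NCc2cccc(Oc3ccccc3)c2)cc1` stands highest of the two numbers so far in a functional assay on CHO cells for agonist activity at Free fatty acid receptor 1 (Homo sapiens) (a lower number here means that less compound is needed, a higher number that more compound is needed for the effect), with compound 3 giving 174 nM. Compound 1 `O=C(O)/C=C/c1ccc(NCc2cccc(Oc3ccccc3)c2)cc1` gives 145 nM, and the step of a 1.2-fold higher number from compound 1 to compound 3 (0.08 log units; within the scatter) is within the scatter. Compound 2 `O=C(O)[C@H]1C[C@@H]1c1ccc(NCc2cccc(Oc3ccccc3)c2)cc1` carries the cyclopropane acid and gives 12.3 nM; 13.5 nM (2 entries) in this assay, the lowest numbers in the set, as seen in the several entries of compound 2 in this assay, 12.3 nM; 13.5 nM (2 entries).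

Compound 4 `O=C(NO)[C@H]1C[C@@H]1c1ccc(NCc2cccc(Oc3ccccc3)c2)cc1` is the next entry: 2-(hydroxycarbamoyl)cyclopropyl in place of 2-(dimethylcarbamoyl)ethyl on an aromatic carbon. Among the compounds with values here, no measured step matches this change directly. Within the data shown here, the one measured step, from the open-chain acid to the open-chain dimethylamide, was small, while the two values of compound 2 against compound 3 show that the cyclopropane acid sits well lower than the open-chain dimethylamide. The hydroxycarbamoyl group is neither of these. The step in this assay is expected to be roughly a 3.5-fold lower number from compound 3 to compound 4 (0.54 log units; beyond the scatter), with the size of that expected step uncertain. Compound 4 is estimated at 50 nM, with a range from 12 nM to 200 nM.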

Compound 4, half-maximal effective concentration: 14.8 nM
Compound 4: the middle estimate sits 3.4-fold (0.53 log units) above what was measured, within the range that was stated.
By their numbers in this assay, from the lowest: compound 4; then compounds 1 and 3 (each within the scatter of the next).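

On this para position, the 2-(hydroxycarbamoyl)cyclopropyl group brings a large drop in this assay, with a 12-fold lower number from compound 3 to compound 4 (1.07 log units; beyond the scatter), and a drop against the unsaturated acid as well, with a 9.8-fold lower number from compound 1 to compound 4 (0.99 log units; beyond the scatter). A carboxylic acid is therefore not required for a low number here, since compound 4, which has none, gives 14.8 nM. The cyclopropane series now holds two end groups with low numbers, the hydroxycarbamoyl of compound 4 and the acid of compound 2, whose values stand as follows: the several entries of compound 2 in this assay, 12.3 nM; 13.5 nM (2 entries)

How much of the drop belongs to the cyclopropane and how much to the hydroxycarbamoyl end remains unresolved, as ring and end group change together in every pair shown. A hydroxycarbamoyl on an open chain, or a primary amide or tetrazole on the cyclopropane, would bear on this.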